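The source may report more compounds than this note shows. Statements on the series, on what has been measured and on what is new or still open speak of the compounds shown alone.

Measured compounds:
Compound 1 `C1CSC(CC[C@@H]2COCCO2)(C[C@@H]2COCCO2)SC1`: in an ADME assay on BHK cells (Mesocricetus auratus) for cytotoxicity, read by XTT assay (a higher number here means that more compound is tolerated, a lower number that less compound is tolerated), compound 1 gives only a limit, > 1000000 nM.
Compound 2 `O=C(O)C[C@H]1COCCO1`: in this assay compound 2 gives only a limit, > 5000000 nM.
Compound 3 `C1CSC(C[C@H]2COCCO2)(C[C@@H]2COCCO2)SC1`: in this assay compound 3 gives only a limit, > 1000000 nM.

None of the three values is a number; each is a limit of this assay. Compound 3 sits at the limit of > 1000000 nM in this assay, at which 2 of the 3 values shown sit, and compound 2 sits at the limit of > 5000000 nM in this assay, at which 1 of the 3 values shown sits. Among the measured compounds shown here, because every value is a limit, the one measured step, a step that the two limits leave unreadable from compound 1 to compound 3, cannot be read; it shows only that both compounds were tolerated up to where the measurement stops.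

Compound 4 `C1CSC(C[C@H]2COCCO2)(C[C@H]2COCCO2)SC1` differs from compound 3 only in configuration: the two compounds have the same atoms and bonds and differ only in configuration as drawn: 1 of 2 stereo elements differ; a stereocentre at a saturated ring carbon is drawn R in compound 3 and S in compound 4. For the measured compounds named here, no measured step speaks to a change of this kind, and the step from compound 1 to compound 3, a larger change in the same part of the molecule, is itself unreadable. With nothing pointing to a change in either direction, the expectation is that compound 4 behaves like compound 3 and is again reported as a limit, so the estimated step that the limit leaves unreadable from compound 3 to compound 4 is none beyond the scatter. The estimate for compound 4 in this assay is therefore 2000000 nM, with a range from 1000000 nM to 5000000 nM.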

Compound 4, half-maximal cytotoxic concentration: > 1000000 nM
Compound 4: a limit, no number (the forecaster's own chance of this, stated with the estimate: 85%); the middle value is on the limit's open side.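

Compound 3 and compound 4 each give only a limit in this assay, not a number, so the step between them cannot be read. The compounds shown leave open the concentration at which any of them harms the cells, and whether the configuration drawn at that saturated ring carbon changes how much compound is tolerated.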